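Two Aziridinyl Quinone Side Chains and a Proposed Third

The source may hold more compounds than are shown below. What is called first, only, known or untested is meant among the compounds shown, and "the series" means these compounds.

Compound 1 `CCCC1=C(N2CC2)C(=O)C(C(COC(N)=O)OC)=C(N2CC2)C1=O`: 5.63
Compound 2 `CC1=C(N2CC2)C(=O)C(Cc2ccccc2)=C(N2CC2)C1=O`: 4.85

Within the data shown here, the two compounds measured so far share a core and differ in the side chains attached to it. In a functional assay on L1210 cells (Mus musculus), with a stated time of 12 days (a lower number here means a less potent compound, a higher number a more potent compound, by a factor of ten per unit of this negative logarithm), compound 1 gives 5.63, while compound 2 gives 4.85. Of the two numbers, compound 2 has the lower one; compound 1 stands higher by a margin beyond the scatter of repeated measurements.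

Compound 3 `COCCC1=C(N2CC2)C(=O)C(C)=C(N2CC2)C1=O` has not been measured. It differs from compound 2 in one place: methoxymethyl in place of phenyl on a saturated chain carbon bound to a double-bonded ring carbon. Cut one bond further out, the same difference reads benzyl to 2-methoxyethyl, so compound 3 carries a chain bearing one hydrogen-bond acceptor where compound 2 carries one six-membered aromatic ring of carbon only.

Among the measured compounds shown here, no step between measured compounds is available, so the direction must be taken from the two values alone. Compound 1 gives the higher value in this assay because it gives 5.63, and its side chain also carries oxygen. A modest upward step is expected, a number 0.35 log units higher from compound 2 to compound 3 (beyond the scatter), possibly just beyond the scatter. Compound 3 is therefore estimated at 5.2, with a range from 4.6 to 5.8.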

Compound 3, logarithm of the reciprocal of the active concentration, log(1/C): 5.57
Estimate against measurement, compound 3: 0.37 log units below; measured number inside the range.
By their numbers in this assay, from the lowest: compound 2; then compounds 3 and 1 (each within the scatter of the next).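

In this assay, among these compounds, the change from benzyl to 2-methoxyethyl gives a number 0.72 log units higher from compound 2 to compound 3 (beyond the scatter), the first step in this set that can be read at a single place, with the methyl on the other side of the shared core the same in both compounds. It shows that, in this assay, a six-membered aromatic ring of carbon only is not needed on the saturated chain carbon bound to a double-bonded ring carbon: methoxymethyl, with no ring, fewer heavy atoms and one hydrogen-bond acceptor, stands there with the higher number. Among the compounds shown here, nothing measured so far speaks to what lies behind this step.

The step removes the ring and brings in the oxygen in one move, so the compounds shown cannot tell which of the two goes with the higher number, and a plain butyl chain at this place, with no oxygen, would separate them. Going by these compounds, whether the ether oxygen can be exchanged also stays open, as a 2-hydroxyethyl or a 2-aminoethyl chain would show.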